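Compound 2 to compound 4: methyl to pyridin-3-yl

The compounds below may be only part of what the source reports. "The series", "measured", "known", "first", "only" and "open" are said of these compounds alone.

In a functional assay on KG-1 cells (Homo sapiens) for cytotoxicity, read by luminescence and CellTiter-Glo, with a stated time of 3 days (on this read-out lower numbers stand for stronger inhibition and higher numbers for weaker inhibition), compound 1 (`N#Cc1ccc(NC(=O)c2ccc(Cl)cc2O)cc1`) gives 1920 nM and compound 2 (`Cc1ccc(C(=O)Nc2ccc(C#N)cc2)c(O)c1`) gives 2560 nM. These two sit together at the high end of the series, while compound 3 (`O=C(Nc1ccc(OC(F)(F)F)c(Cl)c1)c1cc(F)ccc1O`) stands clearly lower at 370 nM.

Compound 4 (`N#Cc1ccc(NC(=O)c2ccc(-c3cccnc3)cc2O)cc1`) carries pyridin-3-yl in place of methyl on an aromatic carbon, meta to a hydroxy group and para to a large group: pyridin-3-yl in place of methyl on an aromatic carbon. Among the measured compounds shown here, the only measured step at this place is a 1.3-fold higher number from compound 1 to compound 2 (0.12 log units; within the scatter), methyl in place of chloro. It lies within the scatter, and no ring-bearing group has been measured here, so the guidance is thin.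

The expected change is a 1.4-fold lower number from compound 2 to compound 4 (0.15 log units; within the scatter), with no step beyond the scatter expected. For compound 4 the estimate is 1800 nM, with an expected range of 500 nM to 6000 nM.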

Compound 4, half-maximal inhibitory concentration: 7940 nM
For compound 4 the middle estimate is 4.4-fold (0.64 log units) below the measured one, outside the stated range (above it).
By their numbers in this assay, from the lowest: compound 3; then compounds 1 and 2 (each within the scatter of the next); then compound 4.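

At this place, meta to a hydroxy group, the change to pyridin-3-yl gives a 3.1-fold higher number from compound 2 to compound 4 (0.49 log units; beyond the scatter) in this assay and thus weakens inhibition, whereas methyl and chloro had stayed within the scatter of each other. Measured against chloro, the same group gives a 4.1-fold higher number from compound 1 to compound 4 (0.62 log units; beyond the scatter) and so also moves the number beyond the scatter. This position is therefore not indifferent to what it carries, at least for this one ring-bearing group. Nothing available accounts for the loss.

On these data alone, whether the ring as such or its nitrogen drives the step stays open. As far as these compounds go, how phenyl, an amine or a carboxylic acid would read at this place also remains unknown.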